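Swapping a methoxymethyl for chloro on the aromatic ring

This account rests on a few compounds, and the source may have more. Where it says the series, first, only, none or still open, it means among the compounds named here.

Compound 3 `COCc1cccc(C[C@H](O)/C=C/[C@H]2COC(=O)N2CCSCCCC(=O)O)c1` gives 24 nM in a functional assay on CHO cells for agonist activity at prostaglandin E2 receptor EP4 subtype (Rattus norvegicus), read by cAMP accumulation and immunoassay, with a stated time of 10 min (on this read-out higher numbers stand for an effect only at larger amounts of compound and lower numbers for an effect already at smaller amounts), the second highest of three numbers: compound 1 `CCCc1cccc(C[C@H](O)/C=C/[C@H]2CSC(=O)N2CCSCCCC(=O)O)c1` gives 6.1 nM, and compound 2 `O=C(O)CCCSCCN1C(=O)OC[C@@H]1/C=C/[C@@H](O)Cc1cccc(-c2ccccc2)c1` gives 450 nM. The change from compound 2 to compound 3 brought a 19-fold lower number from compound 2 to compound 3 (1.27 log units; beyond the scatter), so a smaller substituent at this aromatic carbon went with a far lower number. Compound 4 `O=C(O)CCCSCCN1C(=O)OC[C@@H]1/C=C/[C@@H](O)Cc1cccc(Cl)c1` differs from compound 3 by chloro in place of methoxymethyl on an aromatic carbon. Going by the values given here, no measured step shows chloro, and only the step from compound 2 to compound 3 bears on the size of this group. Compound 4 is therefore expected to give 12 nM, within 3 nM to 45 nM, a change of a 2.0-fold lower number from compound 3 to compound 4 (0.30 log units; within the scatter) that may stay within the scatter.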

Compound 4, half-maximal effective concentration: 23 nM
For compound 4 the middle estimate is 1.9-fold (0.28 log units) below the measured one; the measured number falls inside the stated range.
By their numbers in this assay, from the lowest: compound 1; then compounds 4 and 3 (each within the scatter of the next); then compound 2.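

Chloro and methoxymethyl, with one heavy atom and three, cannot be told apart at this aromatic carbon: a 1.0-fold lower number from compound 3 to compound 4 (0.02 log units; within the scatter). Chloro also stands well clear of phenyl, with a 20-fold lower number from compound 2 to compound 4 (1.29 log units; beyond the scatter), so the low number seen with methoxymethyl does not depend on that group's oxygen. No evidence at hand gives a reason for this. Still open, from the compounds shown here alone, is how large a group this carbon tolerates before the number rises, and whether an amine or a longer chain here would match chloro or phenyl.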